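Amide variation on a dimethoxyphenyl scaffold: cyclohexyl to phenyl

The source may report more compounds than this note shows. Statements on the series, on what has been measured and on what is new or still open speak of the compounds shown alone.

Measured compounds:
compound 1, `COc1ccc(-c2cn3cc(C4=CCN(S(=O)(=O)CCc5ccccc5)CC4)ccc3n2)cc1OC`, 8080 nM
compound 2, `COc1ccc(-c2cn3cc(C4=CCN(C(=O)c5ccccc5C(F)(F)F)CC4)ccc3n2)cc1OC`, 8110 nM
compound 3, `COc1ccc(-c2cn3cc(C4=CCN(C(=O)C5CCCCC5)CC4)ccc3n2)cc1OC`, 10900 nM

Of the compounds shown here, three sharing one core have been tested in a functional assay on B16-F10 cells (Mus musculus) for antiproliferative activity, read by MTT assay, with a stated time of 48 h; on this read-out higher numbers stand for weaker inhibition and lower numbers for stronger inhibition. Compound 1 gives 8080 nM, compound 2 gives 8110 nM, and compound 3 gives 10900 nM. Compound 3 has the highest number of the three, yet its nearest neighbour is compound 2 at a 1.3-fold higher number from compound 2 to compound 3 (0.13 log units; within the scatter) and the other is compound 1 at a 1.3-fold higher number from compound 1 to compound 3 (0.13 log units; within the scatter), so all three sit within the scatter of one another and no ordering can be read from them.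

The unmeasured compound 4, `COc1ccc(-c2cn3cc(C4=CCN(C(=O)c5ccccc5)CC4)ccc3n2)cc1OC`, differs from compound 3 by phenyl in place of cyclohexyl on a carbonyl carbon. The most relevant measured step is the change on the same carbonyl carbon, a 1.3-fold higher number from compound 2 to compound 3 (0.13 log units; within the scatter), which swaps an aromatic ring for the saturated one and stays within the scatter; the swaps of the whole amine substituent, a 1.0-fold higher number from compound 1 to compound 2 (0.00 log units; within the scatter) and a 1.3-fold higher number from compound 1 to compound 3 (0.13 log units; within the scatter), also stay within the scatter. On this evidence no step beyond the scatter is expected for compound 4, so a 1.2-fold lower number from compound 3 to compound 4 (0.08 log units; within the scatter) is estimated as essentially flat. Compound 4 is expected to give about 9000 nM in this assay, in a range of 4000 nM to 20000 nM.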

Compound 4, half-maximal inhibitory concentration: 8370 nM
Estimate against measurement, compound 4: 1.1-fold (0.03 log units) above; measured number inside the range.
By their numbers in this assay, from the lowest: compounds 1, 2, 4 and 3 (each within the scatter of the next).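

In this assay, phenyl in place of cyclohexyl on the carbonyl carbon gives a 1.3-fold lower number from compound 3 to compound 4 (0.11 log units; within the scatter), so turning this non-aromatic ring into an aromatic one, with the same count of heavy atoms, produces no readable change at this position. Hydrogen in place of trifluoromethyl on the aromatic carbon gives a 1.0-fold higher number from compound 2 to compound 4 (0.01 log units; within the scatter), which shows that the unsubstituted benzoyl group can be read no differently from its trifluoromethyl-bearing counterpart. Benzoyl in place of phenethylsulfonyl on the amine nitrogen in a ring gives a 1.0-fold higher number from compound 1 to compound 4 (0.02 log units; within the scatter), so all of the changes seen at this nitrogen remain within the scatter.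

The compounds shown leave open whether an amine or a carboxylic acid on the phenyl ring, or a longer chain on the carbonyl carbon, would produce a step beyond the scatter. With every step this small, they also do not identify any feature of this substituent that governs the read-out. No available evidence accounts for this flat result.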